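Swapping a Benzyl for 4-Methoxyphenyl on the Ring Nitrogen

A few compounds are considered here, and "the series" means these few. Any claim that something is new, unique, unknown or untested is made for them only; others in the source may bear on it.

Measured so far:
Compound 1, `O=[N+]([O-])c1cc(C[S+]([O-])c2nnnn2C2CCCCC2)cc([N+](=O)[O-])c1`, gives > 30000 nM in an ADME assay on MDCK-II cells (Canis lupus familiaris) for cytotoxicity, read by MTT assay, with a stated time of 48 h (a higher number here means a weaker inhibitor, a lower number a stronger inhibitor), and this reading is a limit of the assay rather than a number.
Compound 2, `O=[N+]([O-])c1cc(C[Se]c2nnnn2Cc2ccccc2)cc([N+](=O)[O-])c1`, gives 22000 nM in this assay.

Among the measured compounds shown here, compound 2 therefore holds the only number recorded; the other reading is a limit, (the limit of > 30000 nM in this assay, at which 1 of the 2 values shown sits). For the measured compounds named here, no pair of measured compounds differs in a single place, so no step has been measured that could serve as a guide.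

Compound 3, `COc1ccc(-n2nnnc2[Se]Cc2cc([N+](=O)[O-])cc([N+](=O)[O-])c2)cc1`, differs from compound 2 in one place: 4-methoxyphenyl in place of benzyl on an aromatic nitrogen. Going by the values given here, with no measured step available for this kind of change, the expected shift in this assay is none beyond the usual scatter, though the uncertainty is wide in both directions. Compound 3 is thus expected to give about 25000 nM, within a range from 9000 nM to 60000 nM. The expected step of a 1.1-fold higher number from compound 2 to compound 3 (0.06 log units; within the scatter) is, in other words, no clear move.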

Compound 3, half-maximal inhibitory concentration: < 7500 nM
Compound 3 gave a limit, no number; the forecaster's own chance of this, stated with the estimate: 40%; middle value at least 3.3-fold (0.52 log units) from the limit.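

The group on the aromatic nitrogen of the five-membered ring can clearly change the reading in this assay: 4-methoxyphenyl in place of benzyl gives an at least 2.9-fold lower number from compound 2 to compound 3 (0.46 log units; beyond the scatter). Among the compounds shown here, this is the first measured comparison here in which only one place changes, and it shows that this position is not silent in these cells. Compound 3 carries a limit of the assay rather than a number, so the step gives only the smallest possible size of the change: the limit of < 7500 nM in this assay, at which 1 of the 3 values shown sits.

The pair cannot tell whether the methoxy group or the replacement of benzyl by a directly attached aromatic ring matters more. A plain phenyl on the same nitrogen would separate these two, and an amine or a carboxylic acid in place of the methoxy group would test how much that spot tolerates.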